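The compounds below may be only part of what the source reports. "The series", "measured", "known", "first", "only" and "open" are said of these compounds alone.

Values so far in a functional assay on SK-BR-3 cells (Homo sapiens) for antiproliferative activity (a higher number here means a weaker inhibitor, a lower number a stronger inhibitor), are as follows.
compound 1 `COc1ccc(C(=O)Nc2cc3ccc(OC4CCN(C)CC4)c(C)c3oc2=O)cc1CC=C(C)C` gives 1410 nM per the read-out
compound 2 `Cc1c(OC2CCN(C)CC2)ccc2cc(NC(=O)c3ccccc3)c(=O)oc12` gives 11500 nM per the read-out
compound 3 `C=CCc1cc(C(=O)Nc2cc3ccc(OC4CCN(C)CC4)c(C)c3oc2=O)ccc1O` gives 2430 nM per the read-out

Compound 1 (1410 nM) lies within the scatter of compound 3 and well below compound 2, so it sits in the better part of this small set. The next compound, compound 4 `CC(C)=CCc1cc(C(=O)Nc2cc3ccc(OC4CCN(C)CC4)c(C)c3oc2=O)ccc1OCCCN(C)C`, differs from compound 1 by one change (2-(dimethylamino)ethyl in place of hydrogen on a saturated chain carbon bound to an oxygen on an aromatic ring), which also reads as methoxy to 3-(dimethylamino)propoxy. Among the measured compounds shown here, no measured step covers this change directly. For the measured compounds named here, the only step in hand (a 4.7-fold lower number from compound 2 to compound 3 (0.68 log units; beyond the scatter)) is modest and concerns the replacement of phenyl on a carbonyl carbon. Compound 3 (2430 nM) bears a free hydroxyl where compound 1 bears methoxy, and a different chain as well, yet the two values stay within the scatter. On that slender evidence, no step beyond the scatter is expected in this assay, in either direction, and the expected step is small (a 1.2-fold lower number from compound 1 to compound 4 (0.07 log units; within the scatter)). Compound 4 is estimated at 1200 nM (350 nM to 4500 nM).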

Compound 4, half-maximal inhibitory concentration: 250 nM
Estimate against measurement, compound 4: 4.8-fold (0.68 log units) above; measured number outside the range, below it.
By their numbers in this assay, from the lowest: compound 4; then compounds 1 and 3 (each within the scatter of the next); then compound 2.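

In this assay, going from methoxy to 3-(dimethylamino)propoxy gives a 5.6-fold lower number from compound 1 to compound 4 (0.75 log units; beyond the scatter), the only step shown at this place on a saturated chain carbon bound to an oxygen on an aromatic ring. The position therefore accepts 2-(dimethylamino)ethyl, with its 5 heavy atoms and no ring, and the number falls rather than rises, so substitution here can move the value beyond the scatter. Nothing measured on these compounds accounts for the step.

Still open, from the compounds shown here alone, is whether the step follows the terminal dimethylamino group or the chain itself: a neutral 3-methoxypropoxy chain would separate the two. A shorter 2-(dimethylamino)ethoxy chain, a longer 4-(dimethylamino)butoxy chain and a terminal morpholine would show how far the step depends on chain length and on the form of the amine.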